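The source may report more compounds than this note shows. Statements on the series, on what has been measured and on what is new or still open speak of the compounds shown alone.

Within the data shown here, in a physicochemical assay for solubility, read by nephelometry, in phosphate buffer, measured as kinetic solubility, with a stated time of 30 min, at pH 6.5 (a higher number here means a more soluble compound, a lower number a less soluble compound), compound 1 (`COc1ccc(-c2cc(-c3ccc(S(C)(=O)=O)cc3)cnc2N)cn1`) gives 121 ug/mL and compound 2 (`Cc1ccc(-c2cc(-c3ccc(S(C)(=O)=O)cc3)cnc2N)cn1`) gives 50 ug/mL as the lower of the two numbers so far. Among the measured compounds shown here, the only measured step is a 2.4-fold lower number from compound 1 to compound 2 (0.38 log units; beyond the scatter) and it places methyl where methoxy stood on an aromatic carbon. It is modest but lies beyond the scatter.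

Compound 3 (`CS(=O)(=O)c1ccc(-c2cnc(N)c(-c3ccc(CO)nc3)c2)cc1`) has not yet been measured. Its difference from compound 2 is hydroxy in place of hydrogen on a saturated chain carbon bound to an aromatic carbon and amounts to hydroxy in place of hydrogen on a saturated chain carbon bound to an aromatic carbon, which reads as methyl to hydroxymethyl. For the measured compounds named here, no measured step covers this exact change. The closest guide is the same step a 2.4-fold lower number from compound 1 to compound 2 (0.38 log units; beyond the scatter) in which the partner carrying oxygen, compound 1, holds the higher number. That is one pair only, so the expectation is weak. A rise in this assay of about that modest size is expected. The expected step is a 2.2-fold higher number from compound 2 to compound 3 (0.34 log units; beyond the scatter) and it carries wide uncertainty. Compound 3 is estimated at 110 ug/mL on a range from 50 ug/mL to 220 ug/mL as the expected reading.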

Compound 3, solubility: 25 ug/mL
Compound 3: middle estimate off by 4.4-fold (0.64 log units), on the high side; the measured number lies below the stated range.
By their numbers in this assay, from the lowest: compounds 3 and 2 (each within the scatter of the next); then compound 1.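

In this assay the entry of hydroxy on a saturated chain carbon bound to an aromatic carbon gives a 2.0-fold lower number from compound 2 to compound 3 (0.30 log units; within the scatter) and so, at this position, methyl to hydroxymethyl leaves compound 2 and compound 3 within the usual scatter of each other. Among these compounds, the single earlier pair had the oxygen-bearing partner holding the higher number, but compound 3 goes against that reading: hydroxymethyl in place of methoxy on an aromatic carbon gives a 4.8-fold lower number from compound 1 to compound 3 (0.68 log units; beyond the scatter) and shows that the presence of oxygen in this substituent does not by itself go with the higher number across these compounds. No supporting data are available to account for the separation of compound 1 from compound 2 and compound 3.

On these data alone, whether the higher number of compound 1 is particular to methoxy remains open, and ethoxy on the same aromatic carbon would test how far that reading extends. As far as these compounds go, it is also open whether an amine or a carboxylic acid in place of hydroxy on the saturated chain carbon would separate from compound 2 in this assay by more than the usual scatter.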